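Amide substituent swap on the indole-bearing pyrimidine series

The compounds below may be only part of what the source reports. "The series", "measured", "known", "first", "only" and "open" are said of these compounds alone.

Three compounds of this series have a result in a functional assay on K562 cells (Homo sapiens) for antiproliferative activity, read by CCK-8 assay, with a stated time of 72 h; on this read-out lower numbers stand for stronger inhibition of growth and higher numbers for weaker inhibition of growth. Compound 1 `CC[C@@H]1C(=O)N(C)c2cnc(-n3ccc4cc(F)ccc43)nc2N1C1CCCC1` gives 21200 nM. Compound 2 `CCC1C(=O)N(C)c2cnc(Nc3ccc(S(=O)(=O)NCCO)cc3)nc2N1c1ccn(C)n1` is reported in this assay as "not active" (no number reported), without a number. Compound 3 `CCC1C(=O)N(C)c2cnc(-n3ccc4cc(C(=O)NCC(C)C)ccc43)nc2N1c1ccn(C)n1` gives 5600 nM, the lowest of the two numbers reported; the gap to compound 1 lies beyond the usual scatter of repeated measurements, and no other pairing in the set is close enough to compare directly.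

The next entry is compound 4 `CCC1C(=O)N(C)c2cnc(-n3ccc4cc(C(=O)NC5CCCC5)ccc43)nc2N1c1ccn(C)n1`, which has not yet been tested in this assay. It differs from compound 3 only at the amide: cyclopentyl in place of isobutyl on an amide-type nitrogen. The shared core, the indole-bearing attachment and the remaining substituents are unchanged, so compound 3 is the only reference point for what compound 4 may do.

Within the data shown here, no measured pair in the set tracks this particular exchange, so the direction of the step cannot be read from the data. Compound 4 is expected to stay near compound 3, with a step from compound 3 to compound 4 estimated as a 1.4-fold lower number from compound 3 to compound 4 (0.15 log units; within the scatter), a change of about the size of the scatter or slightly beyond it. Compound 4 is accordingly estimated at 4000 nM, in a range from 1500 nM to 12000 nM.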

Compound 4, concentration for 50% growth inhibition: 31300 nM
Compound 4: the middle estimate sits 7.8-fold (0.89 log units) below what was measured; measured number above the stated range.
By their numbers in this assay, from the lowest: compound 3; then compounds 1 and 4 (each within the scatter of the next).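

In this assay, among these compounds, the substituent on the amide-type nitrogen proves not to be a silent site: cyclopentyl in place of isobutyl gives a 5.6-fold higher number from compound 3 to compound 4 (0.75 log units; beyond the scatter) and so marks the first single-place change with a measured outcome. Among the two groups seen here, the open-chain isobutyl of compound 3 carries the lower number at 5600 nM while the ring of compound 4 sits at 31300 nM so inhibition of growth in these cells depends on what this nitrogen bears. Nothing available bears on the reason for this step, which stands as an observation without a stated cause.

With one pair carrying the change, the effect of closing a ring cannot be told apart from that of the added carbon, and a single step gives no trend across the position. Open questions are how the position responds to a smaller group such as methyl, a longer chain such as n-hexyl, an open-chain isomer such as neopentyl, or a chain ending in an amine or a carboxylic acid.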